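The compounds below may be only part of what the source reports. "The series", "measured", "known", "first", "only" and "open" are said of these compounds alone.

Measured so far in a functional assay on HepG2 cells for inhibition of squalene monooxygenase (Homo sapiens); on this read-out higher numbers stand for weaker inhibition and lower numbers for stronger inhibition: compound 1 `CCN(C/C=C/C#CC(C)(C)C)Cc1cccc(OCCN(C)S(=O)(=O)c2cc(Br)cs2)c1` gives 300 nM; compound 2 `CCN(C/C=C/C#CC(C)(C)C)Cc1cccc(OCCN(C)S(=O)(=O)c2cc(-c3ccsc3)cs2)c1` gives 90 nM; compound 3 `CCN(C/C=C/C#CC(C)(C)C)Cc1cccc(OCCN(C)S(=O)(=O)c2ccc(-c3ccsc3)s2)c1` gives 210 nM.

Compound 3 holds the second highest number of the three, within the scatter of compound 1. For the measured compounds named here, the only step beyond the scatter that touches compound 3 is a 2.3-fold higher number from compound 2 to compound 3 (0.37 log units; beyond the scatter).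

Compound 4 `CCN(C/C=C/C#CC(C)(C)C)Cc1cccc(OCCN(C)S(=O)(=O)c2ccc(-c3cccs3)s2)c1` differs from compound 3 by thiophen-2-yl in place of thiophen-3-yl on an aromatic carbon. Going by the values given here, no measured step bears on this change directly: a 3.3-fold lower number from compound 1 to compound 2 (0.52 log units; beyond the scatter) exchanges bromo for thiophen-3-yl, and a 2.3-fold higher number from compound 2 to compound 3 (0.37 log units; beyond the scatter) exchanges 4-(thiophen-3-yl)thiophen-2-yl for 5-(thiophen-3-yl)thiophen-2-yl, the thiophen-3-yl group staying in both. Among the compounds with values here, with no comparable step on record, no step beyond the scatter is expected. The expected step is no change at the digits printed from compound 3 to compound 4 (within the scatter). Compound 4 is therefore estimated at 210 nM in this assay, range 100 nM to 450 nM.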

Compound 4, half-maximal inhibitory concentration: 10000 nM
Compound 4: the middle estimate sits 48-fold (1.68 log units) below what was measured; the measured number lies above the stated range.
By their numbers in this assay, from the lowest: compound 2; then compounds 3 and 1 (each within the scatter of the next); then compound 4.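

In this assay, this position tolerates bromo and thiophen-3-yl groups but not every thiophene: thiophen-2-yl in place of thiophen-3-yl, the same atoms joined differently, gives a 48-fold higher number from compound 3 to compound 4 (1.68 log units; beyond the scatter). With a 110-fold higher number from compound 2 to compound 4 (2.05 log units; beyond the scatter) and a 33-fold higher number from compound 1 to compound 4 (1.52 log units; beyond the scatter), compound 4 is the weakest of the four, so the way the outer thiophene is joined outweighs every earlier change in the series. Nothing available explains this loss.

On these data alone, it remains open whether 4-(thiophen-2-yl)thiophen-2-yl on the sulfonyl sulfur would show the same loss. As far as these compounds go, how a phenyl or furan-3-yl group would read in this place also remains open.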